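Phenoxymethyl in place of pyridin-3-yl on a triple-bonded carbon

The source may hold more compounds than are shown below. What is called first, only, known or untested is meant among the compounds shown, and "the series" means these compounds.

In an ADME assay on HepG2 cells (Homo sapiens) for cytotoxicity, read by MTT assay, with a stated time of 72 h (a lower number here means that less compound is tolerated, a higher number that more compound is tolerated), compound 1 `O=[N+]([O-])c1c(CS(=O)(=O)c2ccccc2)nc2c(C#Cc3ccccc3)cc(Cl)cn12` gives > 3900 nM as a limit and not a number. On these data alone, compound 2 `O=[N+]([O-])c1c(CS(=O)(=O)c2ccccc2)nc2c(C#Cc3cccnc3)cc(Cl)cn12` gives > 3900 nM as a limit too, so its exact standing is unknown. Compound 3 `O=[N+]([O-])c1c(CS(=O)(=O)c2ccccc2)nc2c(C#CCOc3ccccc3)cc(Cl)cn12` departs from compound 2 by phenoxymethyl in place of pyridin-3-yl on a triple-bonded carbon in all. Among the compounds with values here, with a step that the two limits leave unreadable from compound 1 to compound 2 as the only measured step and the limit of > 3900 nM in this assay, at which 2 of the 2 values shown sit, as the whole evidence, no step beyond the scatter is expected in this assay for compound 3, and no direction can be given. The expected step that the limit leaves unreadable from compound 2 to compound 3 is therefore a nominal one. For compound 3 the estimate is 5000 nM with an expected range from 2000 nM to 15000 nM as its span.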

Compound 3, half-maximal cytotoxic concentration: 8400 nM
Compound 3: the middle estimate sits 1.7-fold (0.23 log units) below what was measured; the measured number falls inside the stated range.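

The steps from compound 1 and from compound 2 to compound 3 cannot be read in this assay, because compound 1 and compound 2 stand only as limits: the limit of > 3900 nM in this assay, at which 2 of the 3 values shown sit.

On these data alone, whether phenoxymethyl differs from phenyl or pyridin-3-yl on a triple-bonded carbon in this read-out, and in which direction, stays open.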